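Triazole for Acid on a Shared Acetophenone Core

A few compounds are considered here, and "the series" means these few. Any claim that something is new, unique, unknown or untested is made for them only; others in the source may bear on it.

Compound 1 `CCCCCCc1cc(C(C)=O)c(O)cc1OCCCCC#N`: 13%
Compound 2 `CCc1cc(C(C)=O)c(O)cc1OCCCC(C)(C)C(=O)O`: 43%
Compound 3 `CCCc1cc(C(C)=O)c(O)cc1OCCCCC(=O)O`: 0%

Three compounds built on the same core were tested in an assay on isolated protein for binding affinity to leukotriene B4 receptor 1 (Homo sapiens), tested at 1 uM; on this read-out higher numbers stand for more inhibition at the one concentration tested (going by the name of the read-out) and lower numbers for less inhibition. Compound 2 stands highest of the three: compound 1 sits lower by a gap beyond the scatter, and compound 3 sits lower still, by a gap also beyond the scatter. For the measured compounds named here, no pair among the three differs in a single place, so none of these gaps can be tied to one change.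

Compound 4 `CCc1cc(C(C)=O)c(O)cc1OCCCCCn1cncn1` has not yet been measured in this assay. It differs from compound 2 in one place: 2-(1H-1,2,4-triazol-1-yl)ethyl in place of 1-carboxy-1-methylethyl on a saturated chain carbon, three bonds along the chain from an oxygen on an aromatic ring. The 1-carboxy-1-methylethyl group leaves and the 2-(1H-1,2,4-triazol-1-yl)ethyl group enters, with one hydrogen-bond donor lost and three acceptors present in its place.

Going by the values given here, with no single-change step among the measured compounds, the expectation rests on what the three numbers show. Compound 1 carries no 1-carboxy-1-methylethyl group and gives 13% in this assay. The step is expected to go downward and beyond the scatter, a number 28 percentage points lower from compound 2 to compound 4 (beyond the scatter). Compound 4 is estimated at 15%, within 0% to 38%.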

Compound 4, a percentage reported as inhibition, at one concentration (the size of the read-out at that concentration, not a potency): 30%
Beside the measured number, compound 4's estimate is 15 percentage points below it, within the range that was stated.
By their numbers in this assay, from the lowest: compound 3; then compound 1; then compound 4; then compound 2.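

In this assay, for the compounds shown here, putting 2-(1H-1,2,4-triazol-1-yl)ethyl in place of 1-carboxy-1-methylethyl on a saturated chain carbon, three bonds along the chain from an oxygen on an aromatic ring, gives a number 13 percentage points lower from compound 2 to compound 4 (beyond the scatter) and is the first step in this set that can be tied to one change. It shows that this position is sensitive to the exchange, yet the read-out does not vanish with the loss of the 1-carboxy-1-methylethyl group: with 0 hydrogen-bond donors in the entering group and a five-membered aromatic ring present, compound 4 still gives 30% at the one concentration tested. No measured evidence bears on why the exchange has this effect.

The change swaps the whole group at once, leaving it open how much of the step belongs to the removal of the carboxylic acid and how much to the arrival of the triazole ring. A tetrazole, an imidazole or a primary amine on the same chain carbon would help to separate the two, as would a carboxylic acid without the two methyl groups.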